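The source may report more compounds than this note shows. Statements on the series, on what has been measured and on what is new or still open speak of the compounds shown alone.

Working notes on the series. Compound 1 `CC1(C)CC(NC(=S)Nc2cccc(Cl)c2)c2cc(NS(C)(=O)=O)ccc2O1`, compound 2 `CC1(C)CC(NC(=S)Nc2ccc(Cl)cc2)c2cc(NS(C)(=O)=O)ccc2O1` and compound 3 `CC1(C)CC(NC(=O)Nc2cccc(Cl)c2)c2cc(NS(C)(=O)=O)ccc2O1` have been tested in a functional assay on thoracic aorta (Rattus norvegicus) for inhibition; on this read-out lower numbers stand for an effect already at smaller amounts and higher numbers for an effect only at larger amounts of compound. Compound 1 gives 9800 nM, compound 2 gives 11600 nM and compound 3 gives 15200 nM. The step of a 1.2-fold higher number from compound 1 to compound 2 (0.07 log units; within the scatter) comes from the change (4-chlorophenyl in place of 3-chlorophenyl on an amide-type nitrogen). The difference between the cores of compound 1 and compound 3 is not broken down here. Compound 4 `CC1(C)CC(NC(=O)Nc2ccc(Cl)cc2)c2cc(NS(C)(=O)=O)ccc2O1` is not yet measured; it arises from compound 3 by 4-chlorophenyl in place of 3-chlorophenyl on an amide-type nitrogen, the same kind of change as in the earlier pair, though here the amide-type nitrogen sits beside a carbonyl carbon rather than a thiocarbonyl carbon. In this assay a step of a 1.2-fold higher number from compound 3 to compound 4 (0.06 log units; within the scatter) is expected, resting on the earlier pair, because a 1.2-fold higher number from compound 1 to compound 2 (0.07 log units; within the scatter) stayed within the scatter. Compound 4 is therefore estimated at 17500 nM, with a range from 9000 nM to 34000 nM.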

Compound 4, half-maximal effective concentration: > 30000 nM
Compound 4 ended at the assay's limit; the forecaster's own chance of this, stated with the estimate: 10%; middle value at least 1.7-fold (0.23 log units) away from the limit.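

In this assay compound 4 gives > 30000 nM, which is a limit of the assay and not a number. The change from 3-chlorophenyl to 4-chlorophenyl on the core of compound 3 amounts to an at least 1.9-fold higher number from compound 3 to compound 4 (0.29 log units; that floor lies within the scatter), and its comparison with the earlier pair remains unresolved: the same change on two cores in this assay, a 1.2-fold higher number (0.07 log units; within the scatter) from compound 1 to compound 2 and an at least 1.9-fold higher number (0.29 log units; that floor lies within the scatter) from compound 3 to compound 4; the limit leaves it open whether they differ. The data therefore show neither that the change carries over unaltered from the core of compound 1 to the core of compound 3 nor that it acts differently there.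

Going by these compounds, the full size of the step on the core of compound 3 remains open. Also open, on these data alone, is how the same change would read with fluorine or methoxy in place of the chlorine on either core.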